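A Nitro Group Replaces Trifluoromethoxy at the Assay Limit

This account rests on a few compounds, and the source may have more. Where it says the series, first, only, none or still open, it means among the compounds named here.

Compound 1 `COc1ccc(C(c2nnn(C)n2)N2CCN(C(=O)c3cc(-c4nc5cc(NC(C)=O)ccc5o4)ccn3)CC2)cc1` and compound 2 `CC(=O)Nc1ccc2oc(-c3ccnc(C(=O)N4CCN(C(c5ccc(OC(F)(F)F)cc5)c5nnn(C)n5)CC4)c3)nc2c1` differ in one place, a trifluoromethyl in place of methyl on an oxygen on an aromatic ring. In an ADME assay on MDCK cells (Canis lupus familiaris) for cytotoxicity (a lower number here means that less compound is tolerated, a higher number that more compound is tolerated), compound 1 gives > 50000 nM, which is a limit of the assay. Compound 2 gives > 50000 nM, which is also a limit and not a number. Compound 2 therefore stands with the limit of > 50000 nM in this assay, at which 2 of the 2 values shown sit.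

Compound 3 `CC(=O)Nc1ccc2oc(-c3ccnc(C(=O)N4CCN(C(c5ccc([N+](=O)[O-])cc5)c5nnn(C)n5)CC4)c3)nc2c1` keeps the rest of compound 2 but carries nitro in place of trifluoromethoxy on an aromatic carbon, para to a large group: nitro in place of trifluoromethoxy on an aromatic carbon. Among the measured compounds shown here, the only measured step nearby is a step that the two limits leave unreadable from compound 1 to compound 2, and it concerns a different change. For the measured compounds named here, it offers no size to carry over, and no measured step covers the nitro group. With no numerical value to work from, no step beyond the scatter is expected in this assay, and no direction can be assigned. The estimate for the change is a number no higher from compound 2 to compound 3 (the limit leaves the size open). Compound 3 is expected at 50000 nM, with an estimated range from 20000 nM to 100000 nM.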

Compound 3, half-maximal cytotoxic concentration: > 50000 nM
Compound 3 was reported as a limit; the forecaster's own chance of this, stated with the estimate: 85%; the middle value lies on the limit itself.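

In this assay compound 3 gives > 50000 nM, which is a limit of the assay and not a number. Among the compounds shown here, no step among compound 1, compound 2 and compound 3 can be read, and all three stand at one limit: the limit of > 50000 nM in this assay, at which 3 of the 3 values shown sit. The compounds shown leave open whether the methoxy, trifluoromethoxy and nitro compounds differ at all in this assay, and at what concentration any of them would reach the half-maximal cytotoxic effect.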